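The compounds below may be only part of what the source reports. "The series", "measured", "known", "first", "only" and "open" are said of these compounds alone.

Compound 1 `Clc1cccc(-c2nc(-c3cccc(C4=NCCN4)c3)no2)c1` gives 1390 nM in an assay for inhibition of Amine oxidase [flavin-containing] A (Homo sapiens), read by fluorescence and spectrophotometry, using microsomes, with stated times of 30 min and 20 min; on this read-out lower numbers stand for stronger inhibition and higher numbers for weaker inhibition. Compound 2 `c1cc(C2=NCCN2)cc(-c2noc(-c3cccs3)n2)c1` gives 88300 nM in this assay, and compound 3 `c1csc(-c2noc(-c3ccc(C4=NCCN4)cc3)n2)c1` gives 1570 nM; the difference between the cores of compound 2 and compound 3 is not broken down here. The change 3-chlorophenyl in place of thiophen-2-yl on an aromatic carbon produced a 64-fold lower number from compound 2 to compound 1 (1.80 log units; beyond the scatter). Compound 4 `Clc1cccc(-c2noc(-c3ccc(C4=NCCN4)cc3)n2)c1` carries the same kind of change, (3-chlorophenyl in place of thiophen-2-yl on an aromatic carbon), though the place differs: in compound 4 the new group sits between two ring nitrogen atoms, two ring bonds from the ring oxygen, whereas in compound 1 it sits next to the ring nitrogen and next to the ring oxygen. Because the earlier change gave a 64-fold lower number from compound 2 to compound 1 (1.80 log units; beyond the scatter), a smaller step is expected for compound 4, namely a 10-fold lower number from compound 3 to compound 4 (1.02 log units; beyond the scatter), since the surroundings of the place are not the same. Compound 4 is estimated at 150 nM, between 30 nM and 700 nM.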

Compound 4, half-maximal inhibitory concentration: 5470 nM
Compound 4: the middle estimate sits 36-fold (1.56 log units) below what was measured, and the stated range ends below it.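

In this assay, putting 3-chlorophenyl in place of thiophen-2-yl on the core of compound 3 gave a 3.5-fold higher number from compound 3 to compound 4 (0.54 log units; beyond the scatter), so the change did not carry over from the earlier core in either direction or size. The two steps stand apart as follows: the same change on two cores in this assay, a 64-fold lower number (1.80 log units; beyond the scatter) from compound 2 to compound 1 and a 3.5-fold higher number (0.54 log units; beyond the scatter) from compound 3 to compound 4, 220-fold (2.35 log units) apart, beyond the scatter of two such steps. This shows that, in these two pairs, the outcome of the change depends on the core that carries it, but it does not show which difference between the cores matters, and two pairs give no rule for any further core.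

Going by these compounds, it remains open how a plain phenyl or a 3-methoxyphenyl would behave in place of thiophen-2-yl on each core. The compounds shown also leave open whether an amine there would follow compound 1 or compound 4.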